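The compounds below may be only part of what the source reports. "The series", "measured", "known", "first", "only" and "open" are said of these compounds alone.

In an ADME assay on L1210/0 cells (Mus musculus) for cytotoxicity, with a stated time of 48 h (on this read-out higher numbers stand for weaker inhibition and lower numbers for stronger inhibition), three compounds that share a core can be compared. Compound 1 `OC[C@H]1C[C@@H](Cn2cnc3c(-c4ccc(Cl)cc4)ncnc32)c2ccccc21` gives 8440 nM, and compound 2 `COc1ccc(-c2ncnc3c2ncn3C[C@@H]2C[C@H](CO)c3ccccc32)cc1` gives 17600 nM. For compound 3 `O[C@H]1C[C@@H](Cn2cnc3c(-c4ccccc4)ncnc32)c2ccccc21` the assay reports only a limit, > 200000 nM. Of the two exact numbers, compound 2 has the higher one, which means the weaker inhibition of that pair, and compound 1 is its nearest neighbour.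

Compound 4 `Cc1ccc(-c2ncnc3c2ncn3C[C@@H]2C[C@H](CO)c3ccccc32)cc1` keeps the framework of compound 2 but carries a methyl in place of methoxy on an aromatic carbon, para to a large group: methyl in place of methoxy on an aromatic carbon. Going by the values given here, only one measured step touches this place: a 2.1-fold higher number from compound 1 to compound 2 (0.32 log units; beyond the scatter), where methoxy took the place of chloro. Among the compounds with values here, that step is modest, and it is the only guide available. A similar or smaller step towards a lower number is therefore expected, and the change may not clear the usual scatter. The estimated change is a 1.5-fold lower number from compound 2 to compound 4 (0.17 log units; within the scatter). For compound 4 the expected value is 12000 nM, with an estimated range of 6000 nM to 25000 nM.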

Compound 4, half-maximal inhibitory concentration: 15400 nM
Estimate against measurement, compound 4: 1.3-fold (0.11 log units) below; the measured number falls inside the stated range.
By their numbers in this assay, from the lowest: compounds 1, 4 and 2 (each within the scatter of the next, the first and the last beyond it). At a limit, above all of these: compound 3.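

On the aromatic carbon para to a large group, methyl and methoxy cannot be told apart in this assay: the change from 4-methoxyphenyl to 4-methylphenyl gives a 1.1-fold lower number from compound 2 to compound 4 (0.06 log units; within the scatter), so this swap has no readable effect. Methyl in place of chloro gives a 1.8-fold higher number from compound 1 to compound 4 (0.26 log units; within the scatter), which also leaves these two compounds indistinguishable, so the only step at this position that clears the scatter is the modest one between chloro and methoxy, with compound 4 falling within the scatter of both. Nothing measured here accounts for how closely these three groups agree at this position. On these data alone, it remains open whether an amine, a carboxylic acid or a longer chain on this carbon would shift the number by more. The three groups compared here span too narrow a range to show how far this position can move the read-out.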